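The source may hold more compounds than are shown below. What is called first, only, known or untested is meant among the compounds shown, and "the series" means these compounds.

Compound 1 `O=C(NC1CCN(c2ncnc3[nH]ncc23)CC1)c1ccc(C(F)(F)F)cc1` gives 5740 nM in an assay on isolated protein for inhibition of serine/threonine-protein kinase PAK 1 (Homo sapiens), read by ADP-Glo, with a stated time of 40 min; a lower number here means a stronger inhibitor, a higher number a weaker inhibitor.
Compound 2 `O=C(NC1CCN(c2ncnc3[nH]ncc23)CC1)c1cccc(Cl)c1Cl` gives 4170 nM.

Of the two numbers, compound 2 shows the lower one, with compound 1 the nearest; the gap between them lies within the scatter, so neither ranks above the other. Compound 3 `O=C(Nc1cccc(Cl)c1)NC1CCN(c2ncnc3[nH]ncc23)CC1` is compound 2 with (3-chlorophenyl)amino in place of 2,3-dichlorophenyl on a carbonyl carbon. Within the data shown here, no step between measured compounds covers such a change, so its size must be guessed. The step expected here is a 1.4-fold lower number from compound 2 to compound 3 (0.14 log units; within the scatter), modest and of uncertain direction. Compound 3 is estimated at 3000 nM, in the range from 700 nM to 13000 nM.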

Compound 3, half-maximal inhibitory concentration: 1240 nM
Beside the measured number, compound 3's estimate is 2.4-fold (0.38 log units) above it; low and high end bracket the measured number.
By their numbers in this assay, from the lowest: compound 3; then compounds 2 and 1 (each within the scatter of the next).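

At this place, on a carbonyl carbon whose other neighbours are amide-type nitrogen, (3-chlorophenyl)amino in place of 2,3-dichlorophenyl gives a 3.4-fold lower number from compound 2 to compound 3 (0.53 log units; beyond the scatter) in this assay, so the number here does respond to the group on this carbonyl carbon. The entering group brings a hydrogen-bond donor and carries one chlorine where the leaving group carries two, so two features change in this single step. Nothing available explains the step.

The compounds shown leave open which of these two features accounts for it. A (2,3-dichlorophenyl)amino group on the same carbonyl carbon would separate them.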